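Moving a Methoxy Group: Compound 3 to Compound 4

The source may report more compounds than this note shows. Statements on the series, on what has been measured and on what is new or still open speak of the compounds shown alone.

Measured in a physicochemical assay for solubility, in phosphate buffer, at pH 7.4; on this read-out higher numbers stand for higher solubility and lower numbers for lower solubility:
- Compound 1 `CCOC(=O)c1c(-c2cccc(F)c2)[nH]c2cc(OC)ccc2c1=O`: > 100000 nM, a limit
- Compound 2 `CCOC(=O)c1c(-c2cccc([N+](=O)[O-])c2)[nH]c2cc(OC)ccc2c1=O`: 13000 nM
- Compound 3 `CCOC(=O)c1c(-c2cccc(OC)c2)[nH]c2cc(OC)ccc2c1=O`: > 100000 nM, a limit

Compound 3 gives only a limit, > 100000 nM, and so sits at the limit of > 100000 nM in this assay, at which 2 of the 3 values shown sit. Compound 4 `CCOC(=O)c1c(-c2ccc(OC)cc2)[nH]c2cc(OC)ccc2c1=O` carries 4-methoxyphenyl in place of 3-methoxyphenyl (4-methoxyphenyl in place of 3-methoxyphenyl on an aromatic carbon). The nearest evidence is an at least 7.6-fold lower number from compound 1 to compound 2 (0.88 log units; beyond the scatter) and an at least 7.6-fold higher number from compound 2 to compound 3 (0.88 log units; beyond the scatter), both beyond the scatter, but both involve nitro, which compound 4 lacks. The swap between fluoro and methoxy is a step that the two limits leave unreadable from compound 1 to compound 3. Among the compounds with values here, no measured step moves a methoxy group. The expected change in this assay, an at least 1.4-fold lower number from compound 3 to compound 4 (0.15 log units; that floor lies within the scatter), stays within the scatter, with any drift toward lower numbers. For compound 4 the estimate is 70000 nM, with an expected range of 20000 nM to 150000 nM.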

Compound 4, solubility: 8000 nM
Compound 4: the middle estimate sits 8.8-fold (0.94 log units) above what was measured; the whole stated range lies above it.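

In this assay the place of the methoxy group matters on its own: with the same atoms, 4-methoxyphenyl in place of 3-methoxyphenyl gives an at least 12-fold lower number from compound 3 to compound 4 (1.09 log units; beyond the scatter). That size is only a floor, since compound 3 gives a limit: the limit of > 100000 nM in this assay, at which 2 of the 4 values shown sit.
Methoxy alone therefore does not hold the number at the limit, as the other steps show: an at least 12-fold lower number from compound 1 to compound 4 (1.09 log units; beyond the scatter) and a 1.6-fold lower number from compound 2 to compound 4 (0.21 log units; within the scatter).

Open, on these data alone, is whether 4-fluorophenyl or 4-nitrophenyl would follow 4-methoxyphenyl. Also open, as far as these compounds go, is what an amine or a longer chain would give in place of the methoxy group.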